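Fluoro for methoxy on the hydroxybenzamide ring of compound 3

The source may report more compounds than this note shows. Statements on the series, on what has been measured and on what is new or still open speak of the compounds shown alone.

Measured so far:
compound 1 `O=C(Nc1ccc(OC(F)(F)F)c(Cl)c1)c1ccc(C(F)(F)F)cc1O` — 380 nM
compound 2 `N#Cc1ccc(NC(=O)c2cc(Cl)ccc2O)c(Cl)c1` — 500 nM
compound 3 `COc1cccc(C(=O)Nc2ccc(C#N)cc2)c1O` — > 10000 nM

In a functional assay on HL-60 cells (Homo sapiens) for cytotoxicity, read by luminescence and CellTiter-Glo, with a stated time of 3 days (a higher number here means a weaker inhibitor, a lower number a stronger inhibitor), compound 1 gives 380 nM and compound 2 gives 500 nM. For compound 3 the value > 10000 nM is a limit of the assay and not a number, so compound 3 sits at the limit of > 10000 nM in this assay, at which 1 of the 3 values shown sits, rather than at any measured point. Among the compounds with values here, compound 3 therefore stands outside the measured range of compound 1 and compound 2, with no step to either of them available.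

Compound 4 `N#Cc1ccc(NC(=O)c2cccc(F)c2O)cc1` differs from compound 3 by one change: fluoro in place of methoxy on an aromatic carbon. Within the data shown here, no measured step covers this change, so its size is unknown. The expectation is a step from compound 3 to compound 4 of an at least 1.2-fold lower number from compound 3 to compound 4 (0.09 log units; that floor lies within the scatter) in this assay, likely within the scatter or only modestly toward a stronger inhibitor, since compound 3 itself is only known as a limit. Compound 4 is expected to give about 8000 nM, with a range from 2000 nM to 30000 nM, and a fair chance that compound 4 again reports only a limit.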

Compound 4, half-maximal inhibitory concentration: 5390 nM
Compound 4: the middle estimate sits 1.5-fold (0.17 log units) above what was measured, within the range that was stated.
By their numbers in this assay, from the lowest: compounds 1 and 2 (each within the scatter of the next); then compound 4. At a limit, above all of these: compound 3.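

With fluoro ortho to a hydroxy group, in this assay compound 4 gives 5390 nM, so this place on the ring now carries a measured number, which the methoxy compound did not provide. Compound 3 stands only at a limit of the assay: the limit of > 10000 nM in this assay, at which 1 of the 4 values shown sits. The change therefore reads only as an at least 1.8-fold lower number from compound 3 to compound 4 (0.26 log units; that floor lies within the scatter), which is a floor and not a size, and the true step may be larger.

Within the data shown here, compounds 1 and 2 differ from compound 4 in more than one place, so no steps to them can be read, and what the changes elsewhere on the core contribute stays open. Also open, from the compounds shown here alone, is whether an amine or a methyl group at this place would give a number nearer that of compound 4 or stay at a limit like compound 3.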